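This account rests on a few compounds, and the source may have more. Where it says the series, first, only, none or still open, it means among the compounds named here.

In an ADME assay on HEK293 cells (Homo sapiens) for cytotoxicity, read by CCK-8 assay and cell counting, with a stated time of 2 days (a higher number here means a weaker inhibitor, a lower number a stronger inhibitor), compound 1 `Oc1cccc(-c2cc(-c3cccs3)nc(-c3ccccc3Cl)c2)c1` gives 2600 nM. Compound 2 `Oc1cccc(-c2cc(-c3ccsc3)nc(-c3cccc(Cl)c3)c2)c1` gives 3180 nM, and these two numbers lie within the usual scatter of repeated measurements, so neither can be ranked above the other. Compound 3 `Oc1cccc(-c2cc(-c3ccsc3)nc(-c3ccccc3Cl)c2)c1`, not yet measured, has the same atoms as compound 2 but carries 2-chlorophenyl in place of 3-chlorophenyl on an aromatic carbon. Compound 1 also carries 2-chlorophenyl and gives 2600 nM, so no change beyond the scatter is expected in this assay. The expected step, a 1.1-fold lower number from compound 2 to compound 3 (0.06 log units; within the scatter), is small. For compound 3 the estimate is 2800 nM, with an expected range from 1500 nM to 5200 nM.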

Compound 3, half-maximal inhibitory concentration: 2720 nM
Estimate against measurement, compound 3: 1.0-fold (0.01 log units) above; measured number inside the range.
By their numbers in this assay, from the lowest: compounds 1, 3 and 2 (each within the scatter of the next).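

With thiophen-3-yl on the core, 2-chlorophenyl in place of 3-chlorophenyl next to the ring nitrogen gives a 1.2-fold lower number from compound 2 to compound 3 (0.07 log units; within the scatter) in this assay, so this change of chlorine position has no readable effect here. With 2-chlorophenyl held fixed, thiophen-3-yl in place of thiophen-2-yl gives a 1.0-fold higher number from compound 1 to compound 3 (0.02 log units; within the scatter) and also has no readable effect. No supporting measurement bears on these results.

These compounds vary only the chlorine position and the thiophene attachment. On these data alone, whether an amine or a carboxylic acid at this position would shift the number remains open.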